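Trifluoromethyl in place of methylamino on the shared core

This account rests on a few compounds, and the source may have more. Where it says the series, first, only, none or still open, it means among the compounds named here.

Three compounds of the series carry a number in a physicochemical assay for lipophilicity; on this read-out higher numbers stand for higher lipophilicity and lower numbers for lower lipophilicity. Compound 1 `O=c1oc(NC2CCCCC2)nc2ccccc12` gives 3.5; compound 2 `CNc1nc2ccccc2c(=O)o1` gives 1.7; compound 3 `CCc1ccc2c(=O)oc(NC(C)C)nc2c1` gives 3.2. Compound 2 stands lowest of the three: compound 3 sits nearest, and compound 1 furthest, both beyond the scatter.

Compound 4 `O=c1oc(C(F)(F)F)nc2ccccc12` is not yet measured. The change from compound 2 is trifluoromethyl in place of methylamino on an aromatic carbon.

Going by the values given here, only one measured step touches the same position of the core: a number 1.80 log units lower from compound 1 to compound 2 (beyond the scatter). It shows that what hangs at this place on the core moves the read-out strongly, but it exchanges one group on a nitrogen for another, while here the methylamino leaves altogether and trifluoromethyl enters. Among the compounds with values here, no measured pair shows this exchange itself.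

With the hydrogen-bond donor and acceptor of the methylamino removed and three fluorines entering, the expectation is a rise well beyond the scatter. Compound 4 is therefore estimated at 3, within 2.4 to 3.6, a step of a number 1.30 log units higher from compound 2 to compound 4 (beyond the scatter) expected from compound 2.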

Compound 4, distribution coefficient: 1.9
Beside the measured number, compound 4's estimate is 1.10 log units above it, and the stated range ends above it.
By their numbers in this assay, from the lowest: compounds 2 and 4 (each within the scatter of the next); then compounds 3 and 1 (each within the scatter of the next).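

In this assay this position also tolerates an exchange that leaves the read-out unresolved: trifluoromethyl in place of methylamino on an aromatic carbon gives a number 0.20 log units higher from compound 2 to compound 4 (within the scatter). Going by these compounds alone, the earlier step at this place, a number 1.80 log units lower from compound 1 to compound 2 (beyond the scatter), showed only that the group on the nitrogen can matter, whereas this pair shows that removing the nitrogen and its hydrogen-bond donor and acceptor need not separate two compounds on this read-out, even with more heavy atoms entering. No supporting measurement accounts for this result.

The compounds shown leave open whether the small step belongs to trifluoromethyl and methylamino in particular or extends to other groups at this carbon. A carboxylic acid, a nitrile or a longer alkyl chain in the same place would test that, and a single pair cannot settle it.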